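Phenoxy to bromo on a thiourea: peroxidase inhibition expected

This account rests on a few compounds, and the source may have more. Where it says the series, first, only, none or still open, it means among the compounds named here.

Measured so far:
compound 1, `COc1ccc(NC(=S)Nc2ccc3[nH]ccc3c2)cc1`, 67.6%
compound 2, `S=C(Nc1ccc(Oc2ccccc2)cc1)Nc1ccc2[nH]ccc2c1`, 73.1%

Compound 2 stands highest of the two numbers in an ADME assay on isolated protein for inhibition of peroxidase (Raphanus sativus), read by fluorescence and Amplex Red, tested at 5 uM (a lower number here means a stronger effect, a higher number a weaker effect of the compound at the concentration tested), with compound 1 nearest at a gap within the scatter. Among the compounds with values here, the only measured step, a number 5.5 percentage points higher from compound 1 to compound 2 (within the scatter), moved nothing beyond the scatter. Compound 3, `S=C(Nc1ccc(Br)cc1)Nc1ccc2[nH]ccc2c1`, differs from compound 2 by bromo in place of phenoxy on an aromatic carbon. Within the data shown here, no measured step bears on this exchange, so nothing beyond the scatter is expected. Compound 3 is therefore expected to give 70%, in the range 52% to 88%, a step of a number 3.1 percentage points lower from compound 2 to compound 3 (within the scatter).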

Compound 3, a percentage reported as activity, at one concentration (the size of the read-out at that concentration, not a potency): 82%
Beside the measured number, compound 3's estimate is 12 percentage points below it; low and high end bracket the measured number.
By their numbers in this assay, from the lowest: compounds 1, 2 and 3 (each within the scatter of the next, the first and the last beyond it).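

In this assay, this position on an aromatic carbon, para to a large group, now gives its first step beyond the scatter: bromo in place of methoxy yields a number 14.4 percentage points higher from compound 1 to compound 3 (beyond the scatter), a weaker effect at the concentration tested. Bromo in place of phenoxy gives only a number 8.9 percentage points higher from compound 2 to compound 3 (within the scatter), so that exchange does not separate the two compounds. Nothing available accounts for either step.

From the compounds shown here alone, whether an amine or a carboxylic acid here would give a stronger effect remains open. So does whether chloro would behave like bromo.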